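The source may report more compounds than this note shows. Statements on the series, on what has been measured and on what is new or still open speak of the compounds shown alone.

In a functional assay on MCF7 cells (Homo sapiens) for cytotoxicity, read by MTT assay, with a stated time of 24 h (on this read-out higher numbers stand for weaker inhibition and lower numbers for stronger inhibition), compound 1 `CCCCC(=O)NC(=S)Nc1nc2cc([N+](=O)[O-])ccc2s1` is reported at > 100000 nM, which is a limit of the assay rather than a number (the limit of > 100000 nM in this assay, at which 1 of the 2 values shown sits). For the measured compounds named here, compound 2 `CCCCC(=O)NC(=S)Nc1nc2cc(N)ccc2s1` gives 44700 nM in this assay, and the single measured step, an at least 2.2-fold lower number from compound 1 to compound 2 (0.34 log units; beyond the scatter), concerns the ring substituent only. Compound 3 `O=C(NC(=S)Nc1nc2cc([N+](=O)[O-])ccc2s1)c1ccccc1` differs from compound 1 by phenyl in place of butyl on a carbonyl carbon; the nitro group is kept. Going by the values given here, no measured step bears on a change at the carbonyl carbon, so the series gives no direction for it. The estimated step is a number no higher from compound 1 to compound 3 (the limit leaves the size open), kept within the scatter. Compound 3 is estimated at 100000 nM, with a range from 30000 nM to 300000 nM.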

Compound 3, half-maximal inhibitory concentration: 41600 nM
Compound 3: the middle estimate sits 2.4-fold (0.38 log units) above what was measured, within the range that was stated.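

In this assay the carbonyl carbon now has a measured direction, with the nitro group kept: phenyl in place of butyl gives an at least 2.4-fold lower number from compound 1 to compound 3 (0.38 log units; beyond the scatter), so a change away from the ring substituent also moves the read-out. On these data alone, the full size of this step stays open because compound 1 stands at a limit: the limit of > 100000 nM in this assay, at which 1 of the 3 values shown sits.

As far as these compounds go, whether phenyl in place of butyl reads the same with amino on the ring stays open. So does the reading of a longer chain or a carboxylic acid at the carbonyl carbon.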